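The compounds below may be only part of what the source reports. "The series", "measured", "known", "first", "only" and "open" are said of these compounds alone.

Compound 1 `CC(C)/N=C(\NC#N)Nc1cccnc1`: 2.5 mg/kg
Compound 2 `CCC(CC)/N=C(\NC#N)Nc1cccnc1`: 20 mg/kg

Among the compounds with values here, in a functional assay on the whole organism (blood, strain Wistar-Okamoto) with Rattus norvegicus as the target, with a stated time of 5 days (a higher number here means that more compound is needed for the effect, a lower number that less compound is needed), compound 2 gives 20 mg/kg, the higher of the two numbers measured so far. Within the data shown here, its nearest neighbour is compound 1, which gives 2.5 mg/kg; the single measured step between the two is an 8.0-fold higher number from compound 1 to compound 2 (0.90 log units; beyond the scatter), so enlarging the branched alkyl on the double-bonded nitrogen went with a higher minimum effective dose.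

The unmeasured compound 3 `CCCC(C)(C)/N=C(\NC#N)Nc1cccnc1` is a further variation at the same place: 1,1-dimethylbutyl in place of pentan-3-yl on a double-bonded nitrogen. Among the measured compounds shown here, the only measured step that bears on this change is an 8.0-fold higher number from compound 1 to compound 2 (0.90 log units; beyond the scatter), which points in one direction only, and compound 3 carries a still larger group than compound 2. On that one step the number for compound 3 is expected to stay at the level of compound 2 or to move somewhat higher, and a step of a 1.5-fold higher number from compound 2 to compound 3 (0.18 log units; within the scatter) is estimated, with a real chance that the change falls within the scatter. For compound 3 in this assay the estimated value is 30 mg/kg, with a range from 8 mg/kg to 110 mg/kg.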

Compound 3, minimum effective dose: 1 mg/kg
Compound 3: middle estimate off by 30-fold (1.48 log units), on the high side; the measured number lies below the stated range.
By their numbers in this assay, from the lowest: compound 3; then compound 1; then compound 2.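

In this assay, the group on the double-bonded nitrogen turns out to move the minimum effective dose in both directions: 1,1-dimethylbutyl in place of pentan-3-yl gives a 20-fold lower number from compound 2 to compound 3 (1.30 log units; beyond the scatter), and the same group also gives a 2.5-fold lower number from compound 1 to compound 3 (0.40 log units; beyond the scatter). Compound 3 carries the largest of the three groups yet has the lowest number, so the rise seen on enlarging isopropyl to pentan-3-yl does not continue, and group size alone does not order these compounds. Compound 3 differs from compound 1 by a propyl in place of hydrogen on the saturated chain carbon bound to the double-bonded nitrogen, so the lowest number goes with the one group of the three in which that carbon bears no hydrogen, though nothing shown here accounts for so large a difference between two closely related alkyl groups.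

The compounds shown leave open whether the low dose depends on that fully substituted carbon or on the length of the propyl chain attached to it. A tert-butyl group, a longer chain such as 1,1-dimethylpentyl, or a cyclohexyl ring at the same place would separate these two readings.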